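This account rests on a few compounds, and the source may have more. Where it says the series, first, only, none or still open, it means among the compounds named here.

Measured so far in an assay on isolated protein for inhibition of DNA topoisomerase 1 (Homo sapiens), tested at 100 uM; on this read-out lower numbers stand for a weaker effect and higher numbers for a stronger effect at the one concentration tested:
compound 1 `Clc1ccc(-c2cc(-c3ccsc3)nc(-c3ccco3)c2)o1` gives 8.2%
compound 2 `Clc1ccc(-c2cc(-c3ccco3)nc(-c3cccs3)c2)o1` gives 16%
compound 3 `Clc1ccc(-c2cc(-c3ccc(Cl)o3)cc(-c3cccs3)n2)cc1` gives 38.9%

Compound 1 holds the lowest of the three numbers in this assay. Its nearest neighbour is compound 2, reached by a number 7.8 percentage points higher from compound 1 to compound 2 (within the scatter), so the two stand within the scatter of each other. Its furthest is compound 3, reached from compound 2 by a number 22.9 percentage points higher from compound 2 to compound 3 (beyond the scatter), a modest but real rise.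

Compound 4 `Clc1cccc(-c2cc(-c3ccc(Cl)o3)cc(-c3ccsc3)n2)c1` is not yet measured in this assay. It differs from compound 1 in one place: 3-chlorophenyl in place of furan-2-yl on an aromatic carbon. The group enters on the aromatic carbon next to the ring nitrogen of the shared core.

Going by the values given here, the step that bears on it is the one from compound 2 to compound 3, where 4-chlorophenyl replaced furan-2-yl and the read-out rose beyond the scatter. The thiophen-3-yl of compound 1 is kept in compound 4; its swap for thiophen-2-yl in the step from compound 1 to compound 2 stayed within the scatter. On that basis compound 4 is expected to read 28%, within 12% to 45%, an estimated rise of a number 19.8 percentage points higher from compound 1 to compound 4 (beyond the scatter) that is expected to clear the scatter.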

Compound 4, a percentage reported as inhibition, at one concentration (the size of the read-out at that concentration, not a potency): 0%
Compound 4: middle estimate off by 28 percentage points, on the high side, outside the stated range (below it).
By their numbers in this assay, from the lowest: compounds 4, 1 and 2 (each within the scatter of the next, the first and the last beyond it); then compound 3.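

Replacing furan-2-yl with 3-chlorophenyl on the aromatic carbon next to the ring nitrogen leaves this assay within the scatter, with a number 8.2 percentage points lower from compound 1 to compound 4 (within the scatter). A chlorophenyl group at this position therefore does not bring a rise in every setting, unlike a number 22.9 percentage points higher from compound 2 to compound 3 (beyond the scatter), although those two steps differ in the chlorophenyl isomer and in the retained thiophene, so neither difference can be singled out. No measurement on hand accounts for the contrast between the steps.

From the compounds shown here alone, it remains open whether 4-chlorophenyl alongside thiophen-3-yl, or 3-chlorophenyl alongside thiophen-2-yl, would carry the rise. Also open, going by these compounds, is how an unsubstituted phenyl, or a phenyl bearing an amine or a carboxylic acid in place of chlorine, would read at this position.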